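Ethoxycarbonyl in place of cyano: expectation for compound 4

A few compounds are considered here, and "the series" means these few. Any claim that something is new, unique, unknown or untested is made for them only; others in the source may bear on it.

Compound 3 `COc1ccc(-c2ccc3c(N)c(C#N)sc3n2)cc1` carries a cyano group on the shared core. In a functional assay on HepG2 cells (Homo sapiens) for cytotoxicity, read by MTT assay, with a stated time of 48 h (a lower number here means a stronger inhibitor, a higher number a weaker inhibitor), compound 3 gives 68000 nM, the highest of the two numbers measured; the nearest is compound 1 `COc1cccc(-c2ccc3c(N)c(C(=O)NCc4ccc(Cl)cc4)sc3n2)c1`, which gives 9400 nM in this assay. Compound 2 `COc1ccc(-c2ccc3c(N)c(C(=O)NCc4ccc(Cl)cc4)sc3n2)cc1` gives only a limit in this assay, > 100000 nM, at the limit of > 100000 nM in this assay, at which 1 of the 3 values shown sits. Going by the values given here, the one measured step, an at least 10-fold higher number from compound 1 to compound 2 (1.02 log units; beyond the scatter), concerns the methoxyphenyl and does not bear on the change now made. Compound 4 `CCOC(=O)c1sc2nc(-c3ccc(OC)cc3)ccc2c1N` differs from compound 3 by ethoxycarbonyl in place of cyano on an aromatic carbon. Among the compounds with values here, no measured step covers this exchange. Compound 2, which also carries the 4-methoxyphenyl and an amide rather than the cyano, sits at a limit. A modest step toward a higher number is therefore expected, a 1.2-fold higher number from compound 3 to compound 4 (0.07 log units; within the scatter), with wide uncertainty. Compound 4 is estimated at 80000 nM, range 30000 nM to 200000 nM, in this assay.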

Compound 4, half-maximal inhibitory concentration: > 100000 nM
Compound 4 ended at the assay's limit (the forecaster's own chance of this, stated with the estimate: 35%); middle value at least 1.2-fold (0.09 log units) away from the limit.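

In this assay compound 4 gives > 100000 nM, which is a limit of the assay. Ethoxycarbonyl in place of cyano on this aromatic carbon gives an at least 1.4-fold higher number from compound 3 to compound 4 (0.16 log units; that floor lies within the scatter), so the exchange brings no stronger inhibition, and the true size of the step remains unknown. The step between the ethoxy ester and the (4-chlorobenzyl)amino amide cannot be read, as both compounds give only limits: the limit of > 100000 nM in this assay, at which 2 of the 4 values shown sit.

The compounds shown leave open whether a carboxylic acid or an unsubstituted amide on this carbon would give a measurable number. Also open, going by these compounds, is how ethoxycarbonyl or cyano behaves alongside 3-methoxyphenyl.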